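This account rests on a few compounds, and the source may have more. Where it says the series, first, only, none or still open, it means among the compounds named here.

Measured in a functional assay on NCI-H1299 cells (Homo sapiens) for antiproliferative activity, read by MTT assay, with a stated time of 48 h; on this read-out lower numbers stand for stronger inhibition and higher numbers for weaker inhibition:
- compound 1 `Cc1ccc2c(c1)C1(C(=O)N2Cc2ccccc2)C(C#N)=C(N)Oc2cc3oc(-c4ccccc4)cc(=O)c3c(O)c21`: > 50000 nM (a limit)
- compound 2 `CCN1C(=O)C2(C(C#N)=C(N)Oc3cc4oc(-c5ccccc5)cc(=O)c4c(O)c32)c2cc(C)ccc21`: > 50000 nM (a limit)

Not yet measured:
- compound 3 `Cc1ccc2c(c1)C1(C(=O)N2)C(C#N)=C(N)Oc2cc3oc(-c4ccccc4)cc(=O)c3c(O)c21`

Compound 2 has no numerical value in this assay, only a limit. Within the data shown here, the evidence on this series so far is the limit of > 50000 nM in this assay, at which 2 of the 2 values shown sit.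

Compound 3 carries hydrogen in place of ethyl on an amide-type nitrogen in a ring.

Among the measured compounds shown here, the only measured step that bears on this change is a step that the two limits leave unreadable from compound 1 to compound 2. It offers no size to carry over, and the data support no direction for the new change. The expected outcome is a number no higher from compound 2 to compound 3 (the limit leaves the size open), which is no clear shift from the limit. Compound 3 is estimated at 50000 nM, with an expected range of 15000 nM to 100000 nM, and it may again be reported only as a limit.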

Compound 3, half-maximal inhibitory concentration: > 50000 nM
Compound 3 was reported as a limit; the forecaster's own chance of this, stated with the estimate: 60%; the middle value sits exactly at the limit.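

The steps among compound 1, compound 2 and compound 3 cannot be read: all three values are limits, so no new size or direction follows. The compounds shown leave open how benzyl, ethyl and hydrogen on the amide-type nitrogen in a ring rank against one another.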